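Cyano in Place of Methyl on the Sulfonyl Aryl

The source may report more compounds than this note shows. Statements on the series, on what has been measured and on what is new or still open speak of the compounds shown alone.

For the measured compounds named here, compound 2 `Cc1ccc(S(=O)(=O)N2N=C(c3ccc(-n4cncn4)cc3)CC2c2ccc(N(C)C)cc2)cc1` gives 27.7% in a functional assay on HCC1806 cells (Homo sapiens) for inhibition, read by sulforhodamine B assay, tested at 10 uM (on this read-out lower numbers stand for less inhibition and higher numbers for more inhibition at the one concentration tested (going by the name of the read-out)), the higher of the two numbers measured so far; compound 1 `CN(C)c1ccc(C2CC(c3ccc(-n4cncn4)cc3)=NN2C(=O)c2ccc(F)cc2)cc1` gives 15.6% in this assay. Going by the values given here, the single measured step, a number 12.1 percentage points higher from compound 1 to compound 2 (beyond the scatter), concerns the group on an amine nitrogen in a ring and so does not bear on the change to compound 3 `CN(C)c1ccc(C2CC(c3ccc(-n4cncn4)cc3)=NN2S(=O)(=O)c2ccc(C#N)cc2)cc1`, which is cyano in place of methyl on an aromatic carbon. Among the compounds with values here, with no measured step touching this part of the structure, the step of a number 0.3 percentage points higher from compound 2 to compound 3 (within the scatter) is expected to remain within the scatter. Compound 3 is therefore estimated at 28%, with a range from 10% to 46%.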

Compound 3, a percentage reported as inhibition, at one concentration (the size of the read-out at that concentration, not a potency): 33.1%
Compound 3: middle estimate off by 5.1 percentage points, on the low side; the measured number falls inside the stated range.
By their numbers in this assay, from the lowest: compound 1; then compounds 2 and 3 (each within the scatter of the next).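

In this assay cyano in place of methyl on the aromatic carbon gives a number 5.4 percentage points higher from compound 2 to compound 3 (within the scatter) and so shows that this position takes a nitrile with no difference that can be told from scatter. The sulfonyl series also now holds its gap to compound 1 with either substituent, as a number 17.5 percentage points higher from compound 1 to compound 3 (beyond the scatter) shows for the cyano member. No measurement offered here accounts for this result. From the compounds shown here alone, whether an amine, a carboxylic acid or a methoxy group at this position would move the number beyond the scatter stays open.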